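The source may report more compounds than this note shows. Statements on the series, on what has been measured and on what is new or still open speak of the compounds shown alone.

Measured in an ADME assay on microsomes from liver (Mus musculus) for metabolic stability; on this read-out lower numbers stand for a shorter-lived compound and higher numbers for a longer-lived compound:
- compound 1 (`NS(=O)(=O)CC(=O)NCCSc1nonc1/C(=N/O)Nc1cccc(C(F)F)c1`): 1.5 h
- compound 2 (`C[C@H](CSc1nonc1/C(=N/O)Nc1ccc(F)c(Br)c1)NC(=O)CS(N)(=O)=O`): 0.537 h
- compound 3 (`NS(=O)(=O)CC(=O)NCCSc1nonc1/C(=N/O)Nc1ccc(F)c(Br)c1`): 1.12 h

Compound 3 shares the upper part of this small range. One measured step reaching it is a 1.3-fold lower number from compound 1 to compound 3 (0.13 log units; within the scatter), and the other is a 2.1-fold higher number from compound 2 to compound 3 (0.32 log units; beyond the scatter). Compound 4 (`C[C@@H](CSc1nonc1/C(=N/O)Nc1ccc(F)c(Br)c1)NC(=O)CS(N)(=O)=O`) differs from compound 3 by methyl in place of hydrogen on a saturated chain carbon bound to an amide-type nitrogen and a saturated chain carbon. Within the data shown here, only the step from compound 2 concerns this place, and read backward, it points to a modest fall in this assay. The step from compound 1 concerns a different place and offers no guide. The expected step is a 1.6-fold lower number from compound 3 to compound 4 (0.20 log units; within the scatter), no larger than the one seen at this place. For compound 4 the estimate is 0.7 h, with an expected range from 0.35 h to 1.4 h.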

Compound 4, half-life: 0.398 h
The estimate for compound 4 lay 1.8-fold (0.25 log units) above the measured number; the measured number falls inside the stated range.
By their numbers in this assay, from the lowest: compounds 4 and 2 (each within the scatter of the next); then compounds 3 and 1 (each within the scatter of the next).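

In this assay, methyl in place of hydrogen on this saturated chain carbon gives a 2.8-fold lower number from compound 3 to compound 4 (0.45 log units; beyond the scatter), so a fall beyond the scatter now appears with the stereocentre drawn either way. The drawn configuration itself separates the two methyl compounds by no more than the scatter, with a 1.3-fold lower number from compound 2 to compound 4 (0.13 log units; within the scatter), and the pair offers a clean reading of it: the fact that compounds 2 and 4 differ only in the configuration as drawn

The compounds shown leave open how a longer chain such as ethyl, or an amine, would behave on this carbon. They also leave open whether methyl brings the same fall with 3-(difluoromethyl)phenyl on the amine nitrogen.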